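Working notes on compounds 1 to 3

A few compounds are considered here, and "the series" means these few. Any claim that something is new, unique, unknown or untested is made for them only; others in the source may bear on it.

Measured so far:
- compound 1 `COc1cc2ncnc(Nc3ccc(F)cc3)c2cc1OCCCCC(=O)Nc1ccc(S(N)(=O)=O)cc1`; in a functional assay on A-431 cells (Homo sapiens) for antiproliferative activity, read by MTT assay, with a stated time of 72 h (on this read-out lower numbers stand for stronger inhibition and higher numbers for weaker inhibition), compound 1 gives 18600 nM
- compound 2 `COc1cc2ncnc(Nc3ccc(OC(F)(F)F)cc3)c2cc1OCCCCC(=O)Nc1ccc(S(N)(=O)=O)cc1`; in this assay compound 2 gives 22500 nM

Compound 2 stands at the highest of the two numbers in this assay, with compound 1 as its nearest neighbour; the step of a 1.2-fold higher number from compound 1 to compound 2 (0.08 log units; within the scatter) is within the scatter, so the two compounds are not separated by this read-out.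

Compound 3 `COc1cc2ncnc(Nc3ccc(C)cc3)c2cc1OCCCCC(=O)Nc1ccc(S(N)(=O)=O)cc1` differs from compound 2 by methyl in place of trifluoromethoxy on an aromatic carbon. Among the compounds with values here, no measured step carries this exchange. Within the data shown here, the only step available, a 1.2-fold higher number from compound 1 to compound 2 (0.08 log units; within the scatter), concerns fluoro against trifluoromethoxy at the same place and did not move the number beyond the scatter; it bears on the present change only in so far as one para-substituent exchange there left the read-out unchanged. On that basis no step beyond the scatter is expected in this assay in either direction, and the expected step is a 1.2-fold lower number from compound 2 to compound 3 (0.07 log units; within the scatter). Compound 3 is estimated at 19000 nM in this assay, with a range from 8000 nM to 45000 nM.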

Compound 3, half-maximal inhibitory concentration: 35500 nM
For compound 3 the middle estimate is 1.9-fold (0.27 log units) below the measured one; measured number inside the range.
By their numbers in this assay, from the lowest: compounds 1, 2 and 3 (each within the scatter of the next).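

In this assay, a third substituent on this aromatic carbon, para to a large group, still does not separate the compounds: methyl in place of trifluoromethoxy gives a 1.6-fold higher number from compound 2 to compound 3 (0.20 log units; within the scatter) and methyl in place of fluoro gives a 1.9-fold higher number from compound 1 to compound 3 (0.28 log units; within the scatter) in this series. The exchange of trifluoromethoxy for methyl removes four of the five heavy atoms and the one hydrogen-bond acceptor of the leaving group, yet this larger change in what is counted at the position also stays unresolved by the read-out. Within the data shown here, what rested on a single pair now holds for all three pairs among fluoro, trifluoromethoxy and methyl, and no compound stands apart from the other two. Nothing at hand accounts for the small differences among these numbers or ties them to any property of the groups.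

As far as these compounds go, all three substituents carry no net charge, so it remains open whether an amine or a carboxylic acid on this aromatic carbon would give a step beyond the scatter. Among these compounds, it also remains open whether a shorter or longer chain in place of the one shared by compounds 1, 2 and 3 would move the number more than any exchange at this position has.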